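Swapping Methoxy for Trifluoromethoxy: What the Data Suggest

The compounds below may be only part of what the source reports. "The series", "measured", "known", "first", "only" and "open" are said of these compounds alone.

Three compounds have been measured in a functional assay on SGC-7901 cells (Homo sapiens) for antiproliferative activity, read by MTT assay, with a stated time of 72 h; a lower number here means a stronger inhibitor, a higher number a weaker inhibitor:
compound 1 `COc1ccc(Oc2c(/C=N\OCc3c(Cl)c(-c4ccc(F)cc4)nn3C)c(C)nn2C)cc1` gives 2840 nM;
compound 2 `Cc1nn(C)c(Oc2ccc(OC(F)(F)F)cc2)c1/C=N\OCc1c(Cl)c(-c2ccc(F)cc2)nn1C` gives 2970 nM;
compound 3 `COc1ccc(Oc2c(/C=N\OCc3c(Cl)c(-c4ccc(Cl)cc4)nn3C)c(C)nn2C)cc1` gives 2010 nM.

Compound 1 and compound 2 differ in one place, (trifluoromethyl in place of methyl on an oxygen on an aromatic ring), and that change produced a 1.0-fold higher number from compound 1 to compound 2 (0.02 log units; within the scatter). Compound 3 differs from compound 1 by chloro in place of fluoro on an aromatic carbon, and this gave a 1.4-fold lower number from compound 1 to compound 3 (0.15 log units; within the scatter). Compound 4 `Cc1nn(C)c(Oc2ccc(OC(F)(F)F)cc2)c1/C=N\OCc1c(Cl)c(-c2ccc(Cl)cc2)nn1C` has not yet been measured; it differs from compound 3 by trifluoromethyl in place of methyl on an oxygen on an aromatic ring, the same change at the same place as between compound 1 and compound 2. Because that earlier step was a 1.0-fold higher number from compound 1 to compound 2 (0.02 log units; within the scatter), a similarly flat step is expected here, a 1.0-fold higher number from compound 3 to compound 4 (0.02 log units; within the scatter). Compound 4 is therefore estimated to give 2100 nM in this assay, most likely between 1000 nM and 4400 nM.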

Compound 4, half-maximal inhibitory concentration: 3220 nM
Compound 4: the middle estimate sits 1.5-fold (0.19 log units) below what was measured, within the range that was stated.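

In this assay, methoxy to trifluoromethoxy on the core of compound 3 gave a 1.6-fold higher number from compound 3 to compound 4 (0.20 log units; within the scatter), and this matches the earlier step on the core of compound 1: the same change on two cores in this assay, a 1.0-fold higher number (0.02 log units; within the scatter) from compound 1 to compound 2 and a 1.6-fold higher number (0.20 log units; within the scatter) from compound 3 to compound 4, 1.5-fold (0.19 log units) apart, within the scatter of two such steps

The chloro for fluoro change, now seen again as a 1.1-fold higher number from compound 2 to compound 4 (0.04 log units; within the scatter), also carries across: the same change on two cores in this assay, a 1.4-fold lower number (0.15 log units; within the scatter) from compound 1 to compound 3 and a 1.1-fold higher number (0.04 log units; within the scatter) from compound 2 to compound 4, 1.5-fold (0.19 log units) apart, within the scatter of two such steps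

Going by these compounds alone, this shows only that neither change moved the number beyond the scatter on these two closely related cores; it does not show that either change is without effect on other cores, and two pairs make no general rule.

Still open, as far as these compounds go, is what a longer chain on that oxygen, or an amine or a carboxylic acid on the aromatic ring, would do. From the compounds shown here alone, whether any replacement at these places moves the number beyond the scatter also remains unknown.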